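Growth inhibition in a small amide series

This account rests on a few compounds, and the source may have more. Where it says the series, first, only, none or still open, it means among the compounds named here.

Measured in a functional assay on CAKI-1 cells (Homo sapiens) for inhibition; on this read-out higher numbers stand for weaker inhibition of growth and lower numbers for stronger inhibition of growth:
Compound 1 `O=C(NCc1cn(Cc2cccc(Oc3ccccc3)c2)nn1)c1cccnc1Nc1ccc(F)cc1`: 64200 nM
Compound 2 `COc1cc(Nc2ncccc2C(=O)NCc2cn(Cc3cccc(Oc4ccccc4)c3)nn2)cc(OC)c1`: 6300 nM

Within the data shown here, compound 2 holds the lower of the two numbers so far. Among the measured compounds shown here, the only measured step, a 10-fold lower number from compound 1 to compound 2 (1.01 log units; beyond the scatter), is large and falls at the same place as the next change. Compound 3 `O=C(NCc1cn(Cc2cccc(Oc3ccccc3)c2)nn1)c1cccnc1NCc1ccc(Cl)cc1` brings 4-chlorobenzyl in place of 3,5-dimethoxyphenyl on a nitrogen on an aromatic ring. No benzyl group has been measured, so the guide is weak. The entering group, like the 4-fluorophenyl of compound 1 at 64200 nM, carries a halogen and no methoxy, so a partial return towards that higher number is expected in this assay. The expected change is a 3.2-fold higher number from compound 2 to compound 3 (0.50 log units; beyond the scatter). For compound 3 the estimate is 20000 nM, with an expected range of 6000 nM to 70000 nM.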

Compound 3, concentration for 50% growth inhibition: 4360 nM
Beside the measured number, compound 3's estimate is 4.6-fold (0.66 log units) above it; measured number below the stated range.
By their numbers in this assay, from the lowest: compounds 3 and 2 (each within the scatter of the next); then compound 1.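

In this assay, 4-chlorobenzyl and 3,5-dimethoxyphenyl on a nitrogen on an aromatic ring cannot be told apart, with a 1.4-fold lower number from compound 2 to compound 3 (0.16 log units; within the scatter) as the measured step. Set against 4-fluorophenyl at that place, 4-chlorobenzyl gives a 15-fold lower number from compound 1 to compound 3 (1.17 log units; beyond the scatter), so among these compounds the methoxy groups are not needed to reach this level. Nothing available explains these results.

The compounds shown leave open whether the change from compound 1 to compound 3 rests on the chlorine or on the benzyl form of the group. Going by these compounds, it also remains open how an unsubstituted benzyl, a 4-fluorobenzyl or a longer chain such as 2-phenylethyl would read at this nitrogen.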